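This account rests on a few compounds, and the source may have more. Where it says the series, first, only, none or still open, it means among the compounds named here.

Working notes on the series. In a functional assay on KB cells (Homo sapiens) for cytotoxicity (on this read-out higher numbers stand for an effect only at larger amounts of compound and lower numbers for an effect already at smaller amounts), compound 1 `COC1=C(C)C(=O)/C(=C(O)/C=C/c2ccccc2OC)C(=O)C1(C)C` gives 2.8 ug/mL and compound 2 `COC1=C(C)C(=O)/C(=C(O)/C=C/c2ccccc2C)C(=O)C1(C)C` gives 1.6 ug/mL. Going by the values given here, these are the only two numbers so far, and they lie within the scatter of each other, so compound 2 has no separate standing.

Next is compound 3 `COC1=C(C)C(=O)/C(=C(O)/C=C/c2ccco2)C(=O)C1(C)C`, which differs from compound 2 as follows: furan-2-yl in place of 2-methylphenyl on a double-bonded chain carbon bound to a double-bonded chain carbon. This puts furan-2-yl in place of 2-methylphenyl on a double-bonded chain carbon bound to a double-bonded chain carbon.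

Among the compounds with values here, only one measured step bears on this change, and only indirectly: a 1.8-fold lower number from compound 1 to compound 2 (0.24 log units; within the scatter), with methyl in place of methoxy on an aromatic carbon. Within the data shown here, that step kept the six-membered aromatic ring, and no measured pair exchanges the ring itself, so the direction of the change is poorly defined. With this single step inside the scatter, no shift beyond the scatter is expected in this assay. The expected step is a 1.3-fold higher number from compound 2 to compound 3 (0.10 log units; within the scatter). For compound 3 the estimated value is 2 ug/mL, with an expected range from 0.7 ug/mL to 6 ug/mL.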

Compound 3, concentration for half-maximal effect: 8.8 ug/mL
For compound 3 the middle estimate is 4.4-fold (0.64 log units) below the measured one; the measured number lies above the stated range.
By their numbers in this assay, from the lowest: compounds 2 and 1 (each within the scatter of the next); then compound 3.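

In this assay, going by these compounds alone, the exchange of the ring itself on a double-bonded chain carbon bound to a double-bonded chain carbon is the first change to move the number beyond the scatter: furan-2-yl in place of 2-methylphenyl shows a 5.5-fold higher number from compound 2 to compound 3 (0.74 log units; beyond the scatter) and furan-2-yl in place of 2-methoxyphenyl shows a 3.1-fold higher number from compound 1 to compound 3 (0.50 log units; beyond the scatter) with the same direction. The earlier exchange of methoxy for methyl on an aromatic carbon stayed within the scatter, so this place responds to replacing the whole six-membered aromatic ring in a way the substituent change on that ring did not show, and the step holds from both compounds carrying that ring. Nothing at hand explains this shift.

On these data alone, it stays open whether the higher number goes with the five-membered ring, with its oxygen or with the loss of the substituent on the six-membered ring, and a plain phenyl or a thiophen-2-yl group at this place would separate these readings. As far as these compounds go, the effect of an amine or a carboxylic acid on the aromatic ring at this place is also open, as is any change to the shared core.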